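Amide in place of alkylamine at the ring nitrogen

A few compounds are considered here, and "the series" means these few. Any claim that something is new, unique, unknown or untested is made for them only; others in the source may bear on it.

Measured compounds:
compound 1, `CNc1nc(-c2ccccc2)nc2c1nnn2Cc1ccccc1Cl`: 191000000 nM
compound 2, `OCCCNc1nc(-c2ccccc2)nc2c1nnn2Cc1ccccc1Cl`: 33000000 nM

In an assay on isolated protein for binding affinity to adenosine receptor A1 (Bos taurus) (a higher number here means a weaker inhibitor, a lower number a stronger inhibitor), compound 2 gives 33000000 nM and so holds the lowest of the two numbers shown; compound 1 gives 191000000 nM, and the only measured step is a 5.8-fold lower number from compound 1 to compound 2 (0.76 log units; beyond the scatter). Compound 3, `COc1ccc(C(=O)Nc2nc(-c3ccccc3)nc3c2nnn3Cc2ccccc2Cl)cc1`, is not yet measured in this assay. It differs from compound 2 by (4-methoxyphenyl)carbonyl in place of 3-hydroxypropyl on a nitrogen on an aromatic ring. Within the data shown here, no measured step bears on this change: the step from compound 1 to compound 2 concerns a lengthening of a saturated chain on that nitrogen, not its replacement by a carbonyl-bearing group, and its size gives no rule for compound 3. The expectation is therefore wide, anchored on compound 2 with no direction beyond the scatter firmly expected, so that the step of a 1.5-fold higher number from compound 2 to compound 3 (0.18 log units; within the scatter) is estimated as roughly neutral. Compound 3 is thus expected to give 50000000 nM in this assay, within a range from 5000000 nM to 500000000 nM.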

Compound 3, inhibition constant: 20000000 nM
Compound 3: middle estimate off by 2.5-fold (0.40 log units), on the high side; the measured number falls inside the stated range.
By their numbers in this assay, from the lowest: compounds 3 and 2 (each within the scatter of the next); then compound 1.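

At the nitrogen on an aromatic ring, the result shows that a (4-methoxyphenyl)carbonyl group, which brings a six-membered aromatic ring of carbon only and a carbonyl, reads no differently from the 3-hydroxypropyl chain in this assay (a 1.7-fold lower number from compound 2 to compound 3 (0.22 log units; within the scatter)). Set against the methyl of compound 1, the same group moves the number in the direction 3-hydroxypropyl did (a 9.6-fold lower number from compound 1 to compound 3 (0.98 log units; beyond the scatter)), so two very different replacements for methyl now stand together. Nothing available explains why these two groups read alike (no supporting measurement accompanies these numbers:).

The compounds shown leave open whether a plain benzoyl or a small acetyl on this nitrogen would read the same as the (4-methoxyphenyl)carbonyl group. They also leave open where an unsubstituted amine would fall relative to methyl.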